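Swapping a piperidine for a fluorophenoxy group

This account rests on a few compounds, and the source may have more. Where it says the series, first, only, none or still open, it means among the compounds named here.

Measured so far:
compound 1 `COc1ccc2[nH]c(C(=O)N3CC(=O)N(Cc4ccccc4)[C@@H](CN4CCC(C)CC4)C3)cc2c1` gives 0.267 h
compound 2 `COc1cccc(CN2C(=O)CN(C(=O)c3cc4cc(OC)ccc4[nH]3)C[C@@H]2c2ccccc2)c1` gives 0.118 h
compound 3 `COc1ccc2[nH]c(C(=O)N3CC(=O)N(Cc4ccccc4)[C@@H](N4CCC(Cc5ccccc5)CC4)C3)cc2c1` gives 0.597 h

In an ADME assay on microsomes from liver (Homo sapiens) for metabolic stability, with a stated time of 30 min, tested at 1 uM (on this read-out lower numbers stand for a shorter-lived compound and higher numbers for a longer-lived compound), compound 1 holds the second highest of the three numbers. Compound 3 sits above it and compound 2 below it, and both gaps are beyond the usual scatter of the method. Compound 4 `COc1ccc2[nH]c(C(=O)N3CC(=O)N(Cc4ccccc4)[C@@H](COc4ccc(F)cc4)C3)cc2c1` is the next compound to be tested in this assay. It differs from compound 1 in one place: 4-fluorophenoxy in place of 4-methylpiperidin-1-yl on a saturated chain carbon bound to a saturated ring carbon. Going by the values given here, since no step between two measured compounds matches this exchange, there is nothing among the measured numbers that tells which way the half-life should move. The step from compound 1 to compound 4 is therefore expected to be modest, a 1.1-fold higher number from compound 1 to compound 4 (0.05 log units; within the scatter), in either direction and possibly none beyond the scatter. On that basis compound 4 is estimated at 0.3 h, with a likely range from 0.12 h to 0.75 h.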

Compound 4, half-life: 0.317 h
The estimate for compound 4 lay 1.1-fold (0.02 log units) below the measured number, within the range that was stated.
By their numbers in this assay, from the lowest: compound 2; then compounds 1, 4 and 3 (each within the scatter of the next, the first and the last beyond it).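

In this assay, putting 4-fluorophenoxy in place of 4-methylpiperidin-1-yl on a saturated chain carbon bound to a saturated ring carbon gives a 1.2-fold higher number from compound 1 to compound 4 (0.07 log units; within the scatter) and so leaves the two half-lives indistinguishable. Going by these compounds alone, this is the first comparison here of two compounds that differ in one place, and it shows that at this position an aromatic ring of carbon only can stand in for a non-aromatic ring with one hetero atom without a difference beyond the scatter. Nothing available here explains why the two compounds match.

A single exchange cannot separate the part played by the fluorine from that of the oxygen link or the aromatic ring, which plain phenoxy or 4-fluorophenyl at this spot could begin to address. On these data alone, how a morpholine or a carboxylic acid would fare at this position also remains open.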